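Piperidinylmethyl in place of a diol amide side chain

The source may hold more compounds than are shown below. What is called first, only, known or untested is meant among the compounds shown, and "the series" means these compounds.

Compound 1: `CC(=O)OCC[C@@H]1C[C@@H](c2ccc(F)c(F)c2)[C@H](NC(=O)c2cc(-c3c(Cl)cnn3C)c(Cl)o2)CN1`, 690 nM
Compound 2: `Cn1ncc(Cl)c1-c1cc(C(=O)N[C@@H]2CN[C@H](CC(=O)NCC(O)CO)C[C@H]2c2ccc(Cl)c(Cl)c2)oc1Cl`, 7090 nM
Compound 3: `Cn1ncc(Cl)c1-c1cc(C(=O)N[C@@H]2CN[C@H](CCNS(C)(=O)=O)C[C@H]2c2ccc(F)c(F)c2)oc1Cl`, 920 nM

Of the compounds shown here, three sharing one core have been measured in a functional assay on HCT-116 cells (Homo sapiens) for antiproliferative activity, read by sulforhodamine B assay, with a stated time of 72 h; on this read-out lower numbers stand for stronger inhibition and higher numbers for weaker inhibition. Compound 2 gives 7090 nM, the highest of the three numbers; its nearest neighbour is compound 3 at 920 nM, and compound 1 lies furthest at 690 nM, both gaps beyond the scatter. Going by the values given here, the one measured step, a 1.3-fold higher number from compound 1 to compound 3 (0.12 log units; within the scatter), changes a different part of the side chain and stays within the scatter.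

Compound 4, `Cn1ncc(Cl)c1-c1cc(C(=O)N[C@@H]2CN[C@H](CCN3CCCCC3)C[C@H]2c2ccc(Cl)c(Cl)c2)oc1Cl`, differs from compound 2 by the change ((piperidin-1-yl)methyl in place of (2,3-dihydroxypropyl)carbamoyl on a saturated chain carbon bound to a saturated ring carbon). Among the compounds with values here, no measured pair mirrors this swap, so the single known step gives little direct guidance. Because compound 2 stands at 7090 nM while compounds 1 and 3 cluster well below it, there is room for the number to move downward. The estimate for compound 4 is 1800 nM, with a range from 400 nM to 7000 nM, meaning an expected step of a 3.9-fold lower number from compound 2 to compound 4 (0.60 log units; beyond the scatter) toward stronger inhibition, held loosely.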

Compound 4, half-maximal inhibitory concentration: 1020 nM
Compound 4: the middle estimate sits 1.8-fold (0.25 log units) above what was measured, and the stated range covers the measured number.
By their numbers in this assay, from the lowest: compounds 1, 3 and 4 (each within the scatter of the next); then compound 2.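

In this assay, going by these compounds alone, the earlier compounds gave only a step within the scatter, and that step changed a different part of the side chain. Within the data shown here, this result gives the first step beyond the scatter at this place, on a saturated chain carbon bound to a saturated ring carbon (a 7.0-fold lower number from compound 2 to compound 4 (0.84 log units; beyond the scatter)), and it shows that the (2,3-dihydroxypropyl)carbamoyl group is not needed for activity here, since a (piperidin-1-yl)methyl group with a six-membered non-aromatic ring and no hydrogen-bond donors takes its place with the number moving toward stronger inhibition. No other measurement available here bears on why the number moves.

The compounds shown leave open whether the step follows from losing the carbamoyl, losing the two hydroxyl groups or gaining the piperidine ring. A morpholine, a dimethylamino group, a carboxylic acid or a longer chain carrying the same piperidine would each separate these readings.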